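A few compounds are considered here, and "the series" means these few. Any claim that something is new, unique, unknown or untested is made for them only; others in the source may bear on it.

Three compounds sharing one core, which differ only in the substituent carried on the aromatic oxygen of the dimethylphenyl ring, have been measured in an assay on CHO cells for displacement of a labelled ligand from Free fatty acid receptor 1 (Rattus norvegicus), read by scintillation counting, with a stated time of 90 min, in the presence of a further agent that is not named here; a lower number here means a stronger inhibitor, a higher number a weaker inhibitor. Compound 1 `Cc1cc(OCCCS(C)(=O)=O)c(Cl)c(C)c1-c1cccc(COc2ccc3c(c2)OC[C@H]3CC(=O)O)c1` gives 110 nM. Compound 2 `Cc1cc(OCCCN2CCCC2=O)cc(C)c1-c1cccc(COc2ccc3c(c2)OC[C@H]3CC(=O)O)c1` gives 170 nM, the second highest of the three numbers. Compound 3 `Cc1cc(OC2CCS(=O)(=O)CC2)c(F)c(C)c1-c1cccc(COc2ccc3c(c2)OC[C@H]3CC(=O)O)c1` gives 270 nM. Compound 2 sits within the usual scatter of both its neighbours: its number is only slightly higher than that of compound 1 and only slightly lower than that of compound 3, so no ordering among the three can be asserted.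

Compound 4 `Cc1cc(OCC2(O)CCS(=O)(=O)CC2)cc(C)c1-c1cccc(COc2ccc3c(c2)OC[C@H]3CC(=O)O)c1` has not yet been measured in this assay. It differs from compound 2 by a single change: 4-hydroxy-1,1-dioxothian-4-yl in place of 2-(2-oxopyrrolidin-1-yl)ethyl on a saturated chain carbon bound to an oxygen on an aromatic ring. The new substituent resembles in part the ring-bound sulfone of compound 3 and the chain sulfone of compound 1, both of which gave numbers close to that of compound 2.

Since every measured variation at this position has fallen within the scatter, no step beyond the scatter is expected from compound 2 to compound 4; the estimated change is a 1.2-fold higher number from compound 2 to compound 4 (0.07 log units; within the scatter). The value for compound 4 in this assay is accordingly expected to be around 200 nM, with a plausible range from 80 nM to 500 nM.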

Compound 4, inhibition constant: 170 nM
The estimate for compound 4 lay 1.2-fold (0.07 log units) above the measured number; low and high end bracket the measured number.
By their numbers in this assay, from the lowest: compounds 1, 2, 4 and 3 (each within the scatter of the next, the first and the last beyond it).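

In this assay, among these compounds, the replacement of 2-(2-oxopyrrolidin-1-yl)ethyl by 4-hydroxy-1,1-dioxothian-4-yl on a saturated chain carbon bound to an oxygen on an aromatic ring gives no change at the digits printed from compound 2 to compound 4 (within the scatter) and this is the first step at this place that can be read with the rest of the molecule unchanged, as compound 1 and compound 3 each differ from compound 2 in more than one place. The exchange swaps a five-membered non-aromatic ring with 0 hydrogen-bond donors and 1 hydrogen-bond acceptor for a six-membered non-aromatic ring with 1 hydrogen-bond donor and 3 hydrogen-bond acceptors, and the number stays within the scatter across that difference in the two groups. Nothing given here accounts for this outcome.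

The compounds shown leave open what the hydroxyl group of the new ring contributes, as no 1,1-dioxothian-4-yl ring without that hydroxyl stands beside compound 4 on the same core. They also leave open whether the same holds for a chain ending in an amine or a carboxylic acid at this place.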